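From pyridin-3-yl to 2,4-dimethylphenyl on compound 2

The compounds below may be only part of what the source reports. "The series", "measured", "known", "first", "only" and "open" are said of these compounds alone.

Going by the values given here, in an ADME assay on J774 cells (Mus musculus) for antiproliferative activity, with a stated time of 72 h (a lower number here means that less compound is needed, a higher number that more compound is needed for the effect), compound 2 `CCCCc1cc2c(=O)c(-c3cccnc3)c(C)[nH]c2cc1OCCOc1ccccc1` gives 23000 nM as the only number available so far. For compound 1 `CCc1c(C)[nH]c2cc(OCCCO)c(Cl)cc2c1=O` the entry reads "not determined" (no result reported) and so offers no comparison, which leaves compound 2 without a measured neighbour to be ranked against. Compound 3 `CCCCc1cc2c(=O)c(-c3ccc(C)cc3C)c(C)[nH]c2cc1OCCOc1ccccc1` keeps the core of compound 2 and carries 2,4-dimethylphenyl in place of pyridin-3-yl on an aromatic carbon. Among the compounds with values here, no step between measured compounds exists to guide a forecast in this assay and the data offer no direct precedent for this exchange. The expected change (a 1.5-fold lower number from compound 2 to compound 3 (0.19 log units; within the scatter)) is therefore small, perhaps toward a lower number but not expected to go beyond the usual scatter. Compound 3 is estimated at 15000 nM in this assay, with an expected range from 4000 nM to 45000 nM for the measurement.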

Compound 3, half-maximal effective concentration: 22000 nM
Beside the measured number, compound 3's estimate is 1.5-fold (0.17 log units) below it; low and high end bracket the measured number.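

In this assay, going by these compounds alone, replacing pyridin-3-yl with 2,4-dimethylphenyl gives a 1.0-fold lower number from compound 2 to compound 3 (0.02 log units; within the scatter), the first reading of any change at this position on the aromatic carbon. Across this one pair, losing the ring nitrogen with its hydrogen-bond acceptor and gaining a carbon-only ring with two methyl groups leaves the two compounds level, so this exchange offers no handle on the number. Nothing measured here accounts for this result.

Within the data shown here, with only two aromatic groups compared at this position, it remains open whether a group such as a carboxylic acid or an amine on that ring, or a small alkyl chain in place of the ring, would read the same. From the compounds shown here alone, the shared butyl and phenoxyethoxy groups also stay constant across this pair, so their contribution remains unknown.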